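The compounds below may be only part of what the source reports. "The series", "measured", "known", "first", "only" and "open" are said of these compounds alone.

Measured so far:
- compound 1 `O=C(/C=C/c1ccc2c(c1)B(O)OC2)c1ccc(Cl)cc1`: 9300 nM
- compound 2 `CSc1ccc(C(=O)/C=C/c2ccc3c(c2)B(O)OC3)cc1`: 10300 nM
- compound 3 `O=C(/C=C/c1ccc2c(c1)B(O)OC2)c1ccc([N+](=O)[O-])cc1`: 9100 nM

All three were tested in a functional assay on HCT-116 cells (Homo sapiens) for cytotoxicity, read by MTT assay, with a stated time of 48 h; a lower number here means a stronger inhibitor, a higher number a weaker inhibitor. Compound 1 sits among values that are indistinguishable from one another: the step of a 1.1-fold higher number from compound 1 to compound 2 (0.04 log units; within the scatter) and the step of a 1.0-fold lower number from compound 1 to compound 3 (0.01 log units; within the scatter) both fall inside the usual scatter, as does a 1.1-fold lower number from compound 2 to compound 3 (0.05 log units; within the scatter). Swapping the group on the aromatic ring of compound 1 for methylsulfanyl or nitro thus left the number essentially unchanged.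

Compound 4 `O=C(/C=C/c1ccc2c(c1)B(O)OC2)c1cccc(O)c1` differs from compound 1 by 3-hydroxyphenyl in place of 4-chlorophenyl on a carbonyl carbon. The three measured steps all concern a change of the group on that same aromatic ring, and none of them moved the number beyond the scatter; none, however, involves a hydroxy group or a shift of the substituent's position, so they give only indirect guidance. On that basis the expected step is no change at the digits printed from compound 1 to compound 4 (within the scatter), which is no change beyond the scatter, with a wide allowance for the unfamiliar group. Compound 4 is therefore estimated at 9300 nM, with a range from 3500 nM to 25000 nM.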

Compound 4, half-maximal inhibitory concentration: 6500 nM
Compound 4: the middle estimate sits 1.4-fold (0.16 log units) above what was measured; the measured number falls inside the stated range.
By their numbers in this assay, from the lowest: compounds 4, 3, 1 and 2 (each within the scatter of the next).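

In this assay, putting 3-hydroxyphenyl in place of 4-chlorophenyl on the carbonyl carbon gives a 1.4-fold lower number from compound 1 to compound 4 (0.16 log units; within the scatter). Unlike the earlier steps, this one brings in a hydrogen-bond donor and changes where the substituent sits on the ring, as the two group names show, yet the number still stays within the usual scatter, so all four groups seen so far give indistinguishable values. No measured information accounts for this flat result.

Compound 4 differs from compound 1 in both the identity of the substituent and its place on the ring, so the contribution of each remains unresolved. Going by these compounds, whether an amine, a carboxylic acid or a longer chain on this ring would move the number beyond the scatter also remains open.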